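From pyridin-2-yl to pyrimidin-5-yl on compound 1

The source may hold more compounds than are shown below. What is called first, only, known or untested is meant among the compounds shown, and "the series" means these compounds.

Measured so far in a physicochemical assay for solubility, using the shake flask method, in phosphate buffer, with a stated time of 24 h, at pH 7.4; a higher number here means a more soluble compound, a lower number a less soluble compound:
- compound 1 `CC(Sc1nc2c(cnn2C)c(=O)n1-c1ccccc1)c1ccccn1` gives 20000 nM
- compound 2 `Cn1ncc2c(=O)n(-c3ccccc3)c(CCc3cccc(F)c3)nc21` gives 126000 nM

Compound 1 has the lower of these two numbers, and its gap to compound 2 lies beyond the usual scatter of repeated measurements. The next compound, compound 3 `CC(Sc1nc2c(cnn2C)c(=O)n1-c1ccccc1)c1cncnc1`, keeps the core of compound 1 and changes one group: pyrimidin-5-yl in place of pyridin-2-yl on a saturated chain carbon bound to a saturated chain carbon and a sulfur. In plain words, this puts pyrimidin-5-yl in place of pyridin-2-yl on a saturated chain carbon bound to a saturated chain carbon and a sulfur. Going by the values given here, no measured pair of compounds shows this swap, so the forecast carries real uncertainty. The expected step of a 2.0-fold higher number from compound 1 to compound 3 (0.30 log units; within the scatter) is a modest rise in this assay and may not clear the usual scatter. The estimate for compound 3 is 40000 nM and the expected range runs from 12000 nM to 130000 nM around that middle.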

Compound 3, solubility: 264000 nM
Compound 3: middle estimate off by 6.6-fold (0.82 log units), on the low side; the whole stated range lies below it.
By their numbers in this assay, from the lowest: compound 1; then compound 2; then compound 3.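

With the core of compound 1 held fixed, putting pyrimidin-5-yl in place of pyridin-2-yl on this saturated chain carbon gives a 13-fold higher number from compound 1 to compound 3 (1.12 log units; beyond the scatter) in this assay, so a change to this one group can move the read-out by a large margin. The change adds no size: each group is a six-membered aromatic ring of 6 heavy atoms with no net charge, and the entering ring holds 2 hetero atoms where the leaving ring holds 1. Nothing measured here accounts for the size of this step.

A single pair cannot separate the number of ring nitrogens from the place where the ring is attached. From the compounds shown here alone, whether a plain phenyl, pyridin-3-yl or pyrimidin-2-yl on the same carbon would give a similar number remains open.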